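Aryl urea swap on the shared core: dichloro to difluoro

This account rests on a few compounds, and the source may have more. Where it says the series, first, only, none or still open, it means among the compounds named here.

Measured compounds:
compound 1 `COc1ccc(-c2cc(NNC(=O)Nc3cc(Cl)nc(OC(C)C)c3)nc3c2cnn3C)cc1`, 2320 nM
compound 2 `Cn1ncc2c(-c3ccc(F)cc3)cc(NNC(=O)Nc3cc(Cl)cc(Cl)c3)nc21`, 4980 nM

In an assay on isolated protein for binding affinity to sphingosine 1-phosphate receptor 2 (Homo sapiens), read by surface plasmon resonance (a lower number here means tighter binding, a higher number weaker binding), compound 2 gives 4980 nM, the highest of the two numbers; compound 1 gives 2320 nM, the nearest, and the gap lies beyond the scatter. Compound 3 `Cn1ncc2c(-c3ccc(F)cc3)cc(NNC(=O)Nc3cc(F)cc(F)c3)nc21` is not yet measured. It differs from compound 2 by 3,5-difluorophenyl in place of 3,5-dichlorophenyl on an amide-type nitrogen. Within the data shown here, no measured pair shows this change, so the direction rests on the change alone. The step from compound 2 to compound 3 is expected to be modest and toward a higher number: a 1.6-fold higher number from compound 2 to compound 3 (0.21 log units; within the scatter). Compound 3 is therefore estimated at 8000 nM, within 3000 nM to 22000 nM.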

Compound 3, dissociation constant: 3980 nM
Beside the measured number, compound 3's estimate is 2.0-fold (0.30 log units) above it, and the stated range covers the measured number.
By their numbers in this assay, from the lowest: compounds 1, 3 and 2 (each within the scatter of the next, the first and the last beyond it).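

In this assay, the swap to 3,5-difluorophenyl in place of 3,5-dichlorophenyl on the amide-type nitrogen gives a 1.3-fold lower number from compound 2 to compound 3 (0.10 log units; within the scatter) and so stays within the scatter. This first matched pair at the position therefore does not separate the two halogen patterns on this core. No supporting data bear on this result.

Still open, from the compounds shown here alone, is whether this position tolerates groups without halogen, such as unsubstituted phenyl or 3,5-dimethoxyphenyl. A larger group such as 3,5-bis(trifluoromethyl)phenyl is equally untested among the compounds shown.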